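Chloro in place of hydrogen on the distal phenyl

This account rests on a few compounds, and the source may have more. Where it says the series, first, only, none or still open, it means among the compounds named here.

Within the data shown here, compound 2 `FC(F)(F)c1ccc(NCc2cn(-c3ccccc3)nc2-c2ccccc2)cc1` is the only member of this pair with a number in an ADME assay on MDBK cells (Bos taurus) for cytotoxicity, read by MTT assay, with a stated time of 72 h; a higher number here means that more compound is tolerated, a lower number that less compound is tolerated: compound 2 gives 34000 nM. Compound 1 `Cc1ccc(-c2nn(-c3ccccc3)cc2CNc2ccc(C(F)(F)F)cc2)cc1` carries a methyl on an aromatic carbon and reaches only a limit of the assay in this assay, > 100000 nM. Among the measured compounds shown here, the single measured step, an at least 2.9-fold lower number from compound 1 to compound 2 (0.46 log units; beyond the scatter), shows that removal of that methyl moves the number down by at least that much, the starting point being a limit (the limit of > 100000 nM in this assay, at which 1 of the 2 values shown sits).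

Compound 3 `FC(F)(F)c1ccc(NCc2cn(-c3ccccc3)nc2-c2ccc(Cl)cc2)cc1` differs from compound 2 by chloro in place of hydrogen on an aromatic carbon. For the measured compounds named here, no measured step involves a chloro; the only recorded step concerns a methyl at an aromatic carbon, and it runs the other way, from a substituted ring to a bare one. Going by the values given here, for the bare-to-chloro step in this assay a move back up, toward or onto the limit, is therefore expected rather than a further fall, though only one pair supports this. Compound 3 is expected at 60000 nM, between 25000 nM and 150000 nM, which means an expected step of a 1.8-fold higher number from compound 2 to compound 3 (0.25 log units; within the scatter).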

Compound 3, half-maximal cytotoxic concentration: 31000 nM
Compound 3: middle estimate off by 1.9-fold (0.29 log units), on the high side, and the stated range covers the measured number.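

Going from phenyl to 4-chlorophenyl, with the chloro on an aromatic carbon para to a large group, gives in this assay a 1.1-fold lower number from compound 2 to compound 3 (0.04 log units; within the scatter), so this position now has a second substituent on record and this change cannot be told apart from the usual scatter. Chloro and hydrogen therefore read alike at this position, while methyl in the same place stands apart from both, with an at least 3.2-fold lower number from compound 1 to compound 3 (0.50 log units; beyond the scatter) alongside the earlier step, and neither compound 2 nor compound 3 goes against that split. Both steps from the methyl compound start from a limit of the assay rather than a number, so they fix only a minimum size and not a true distance: the limit of > 100000 nM in this assay, at which 1 of the 3 values shown sits.

Open, from the compounds shown here alone, is whether an ethyl or a methoxy on this aromatic carbon would read like methyl or like chloro and hydrogen, and how an amine or a carboxylic acid there would read. Also open, going by these compounds, is whether the chloro step would stay within the scatter once the trifluoromethyl elsewhere in the core is exchanged for a nitrile.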